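The source may report more compounds than this note shows. Statements on the series, on what has been measured and on what is new or still open speak of the compounds shown alone.

Measured so far:
compound 1 `Clc1ccc2[nH]cc(Sc3ccccc3)c2c1`: > 200000 nM
compound 2 `Cc1ccccc1Sc1c[nH]c2ccc(Cl)cc12`: 21000 nM

In an assay on isolated protein for inhibition of Indoleamine 2,3-dioxygenase 1 (Homo sapiens), read by HPLC, with a stated time of 60 min, in the presence of a further agent that is not named here (a lower number here means a stronger inhibitor, a higher number a weaker inhibitor), compound 1 gives > 200000 nM, which is a limit of the assay and not a number. Compound 1 therefore sits at the limit of > 200000 nM in this assay, at which 1 of the 2 values shown sits, and only a limit marks where it stands. Compound 2 gives 21000 nM in this assay. Within the data shown here, the one measured step, an at least 9.5-fold lower number from compound 1 to compound 2 (0.97 log units; beyond the scatter), follows a methyl added on an aromatic carbon of the shared core, and it moves the number down.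

Compound 3 `Cc1ccc(Sc2c[nH]c3ccc(Cl)cc23)cc1` differs from compound 1 by methyl in place of hydrogen on an aromatic carbon. The step to compound 2 is the only one that bears on this change, and it points to a lower number; the methyl of compound 3 sits at a different place, so the size is uncertain. The step from compound 1 to compound 3 is expected to be an at least 3.3-fold lower number from compound 1 to compound 3 (0.52 log units; beyond the scatter), downward. Compound 3 is expected at 60000 nM, within a range of 15000 nM to 250000 nM.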

Compound 3, half-maximal inhibitory concentration: > 200000 nM
Compound 3 was reported as a limit; the forecaster's own chance of this, stated with the estimate: 35%; at least 3.3-fold (0.52 log units) between middle value and limit.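

Compound 3 gives [ > 200000 nM ], a limit of the assay and not a number. Among these compounds, compound 1 also stands at a limit, so no step between compound 1 and compound 3 can be read: the limit of > 200000 nM in this assay, at which 2 of the 3 values shown sit. The compounds shown leave open whether a methyl para to a large group changes the number at all.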